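A few compounds are considered here, and "the series" means these few. Any claim that something is new, unique, unknown or untested is made for them only; others in the source may bear on it.

Measured so far, in a functional assay on HeLa cells (Homo sapiens) for cytotoxicity, read by WST assay, with a stated time of 48 h; on this read-out lower numbers stand for stronger inhibition and higher numbers for weaker inhibition:
Compound 1 `O[C@@H](c1ccccc1)[C@H]1CO[C@H](c2ccccc2)[C@@H](C/C=C/c2ccccc2)C1` gives 6060 nM.
Compound 2 `COc1ccccc1/C=C/C[C@H]1C[C@@H]([C@@H](O)c2ccccc2)CO[C@@H]1c1ccccc1` gives 14700 nM.
Compound 3 `COc1cccc([C@H](O)[C@H]2CO[C@@H](c3ccc(OC)c(OC)c3)[C@H](C/C=C/c3ccc(OC)c(OC)c3)C2)c1` gives 18600 nM.

Compound 4 `COc1ccc(/C=C/C[C@@H]2C[C@@H]([C@@H](O)c3ccc(OC)c(OC)c3)CO[C@H]2c2ccc(OC)c(OC)c2)cc1OC` has not yet been measured. Compound 2 differs from compound 1 by methoxy in place of hydrogen on an aromatic carbon, and that change gave a 2.4-fold higher number from compound 1 to compound 2 (0.38 log units; beyond the scatter). Compound 4 differs from compound 3 by methoxy in place of hydrogen on an aromatic carbon, the same kind of change, though here the entering group sits ortho to a methoxy group and para to a large group, whereas in compound 2 it sits ortho to a large group. The difference between the core of compound 1 and the core of compound 3 is not broken down here. Compound 3 already stands at the highest number of the three. Because the same kind of change gave a 2.4-fold higher number from compound 1 to compound 2 (0.38 log units; beyond the scatter), the step from compound 3 to compound 4 is expected to be a 1.6-fold higher number from compound 3 to compound 4 (0.21 log units; within the scatter). Compound 4 is therefore estimated at 30000 nM, with a range of 12000 nM to 75000 nM.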

Compound 4, half-maximal inhibitory concentration: 30600 nM
Compound 4: middle estimate off by 1.0-fold (0.01 log units), on the low side; measured number inside the range.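

In this assay, the step of a 1.6-fold higher number from compound 3 to compound 4 (0.22 log units; within the scatter) comes from methoxy replacing hydrogen on an aromatic carbon, and it does not differ from the earlier step on the other core: the same change on two cores in this assay, a 2.4-fold higher number (0.38 log units; beyond the scatter) from compound 1 to compound 2 and a 1.6-fold higher number (0.22 log units; within the scatter) from compound 3 to compound 4, 1.5-fold (0.17 log units) apart, within the scatter of two such steps

The change therefore carries across these two cores with a step of comparable size, although only the earlier step lies beyond the scatter. This rests on just two pairs, with the entering methoxy at a different place in each, so it does not separate the effect of place from that of core, and it gives no cause.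

The aromatic rings shown carry only hydrogen or methoxy. From the compounds shown here alone, how a hydroxy group, a fluorine atom or an amine would compare at those places remains open, as does an ethoxy group or a longer chain in place of methoxy.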